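Aryl swap on the ring amine nitrogen, compound 2 to 4

This account rests on a few compounds, and the source may have more. Where it says the series, first, only, none or still open, it means among the compounds named here.

Three compounds of the series carry numbers in a functional assay on SH-SY5Y cells (Homo sapiens) for inhibition, read by sulforhodamine B assay; a lower number here means a stronger inhibitor, a higher number a weaker inhibitor. Compound 1 `COC(=O)CC/C(C)=C/Cc1c(OC)c(C)c2c(c1OCC#CCN1CCN(C(c3ccccc3)c3ccccc3)CC1)C(=O)OC2` gives 23700 nM, compound 2 `COC(=O)CC/C(C)=C/Cc1c(OC)c(C)c2c(c1OCC#CCN1CCN(c3ccc(C#N)cc3)CC1)C(=O)OC2` gives 37800 nM, and compound 3 `CCCCNc1ccc(CC#CCOc2c(C/C=C(\C)CCC(=O)OC)c(OC)c(C)c3c2C(=O)OC3)cc1` gives 5960 nM. Compound 2 has the highest number of the three; its gap to compound 1 lies within the scatter, while compound 3 stands beyond the scatter with the lower number. Compound 4 `COC(=O)CC/C(C)=C/Cc1c(OC)c(C)c2c(c1OCC#CCN1CCN(c3ccccc3F)CC1)C(=O)OC2` has not been measured in this assay. It differs from compound 2 in one place: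
2-fluorophenyl in place of 4-cyanophenyl on an amine nitrogen in a ring
Among the compounds with values here, no measured pair here differs in this one place, so the size of such a step has no anchor. The expected step, a 1.4-fold lower number from compound 2 to compound 4 (0.13 log units; within the scatter), is taken to lie within the scatter, with no direction asserted. In this assay compound 4 is therefore estimated at 28000 nM, with a range from 9000 nM to 85000 nM.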

Compound 4, half-maximal inhibitory concentration: 35800 nM
Estimate against measurement, compound 4: 1.3-fold (0.11 log units) below, and the stated range covers the measured number.
By their numbers in this assay, from the lowest: compound 3; then compounds 1, 4 and 2 (each within the scatter of the next).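

In this assay, within the data shown here, a 1.1-fold lower number from compound 2 to compound 4 (0.02 log units; within the scatter) gives the first measured step at this amine nitrogen in a ring. The exchange of 4-cyanophenyl for 2-fluorophenyl removes the nitrile and its hydrogen-bond acceptor, yet the step stays within the scatter, so this read-out does not separate these two aryl groups at this position. Nothing available accounts for the size of this step. Still open, going by these compounds, is how a plain phenyl, a 4-fluorophenyl or a 4-carboxyphenyl would read here. On these data alone, a methyl or an acetyl on this nitrogen, with no aryl ring, also remains untested in these compounds.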